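The source may report more compounds than this note shows. Statements on the series, on what has been measured and on what is new or still open speak of the compounds shown alone.

Series notes. In a functional assay on CHO cells for agonist activity at Alpha-1D adrenergic receptor (Homo sapiens), read by FLIPR and calcium flux (a higher number here means that more compound is needed for the effect, a lower number that less compound is needed), compound 1 `c1ccc(-c2cccc3c2CCC3c2ncc[nH]2)nc1` gives > 10000 nM, which is a limit of the assay and not a number. Compound 2 `COc1cccc2c1CCC2c1ncc[nH]1` gives > 10000 nM, likewise a limit. Compound 3 `CNC(=O)c1cccc2c1CCC2c1ncc[nH]1` gives > 10000 nM, again only a limit. On the numbers shown, compound 3 therefore stands at the limit of > 10000 nM in this assay, at which 3 of the 3 values shown sit, with nothing to rank it against. Compound 4 `CCS(=O)(=O)Nc1cccc2c1CCC2c1ncc[nH]1` differs from compound 3 by (ethylsulfonyl)amino in place of methylcarbamoyl on an aromatic carbon. For the measured compounds named here, the steps that bear on this change, a step that the two limits leave unreadable from compound 1 to compound 3 and a step that the two limits leave unreadable from compound 2 to compound 3, are unreadable in size, as is a step that the two limits leave unreadable from compound 1 to compound 2, due to the limit of > 10000 nM in this assay, at which 3 of the 3 values shown sit. With three substituents at this carbon leaving the limit unbroken, no step beyond the scatter is expected in this assay. Compound 4 is expected at 10000 nM, within 3000 nM to 30000 nM. This amounts to an expected step of a number no higher from compound 3 to compound 4 (the limit leaves the size open).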

Compound 4, half-maximal effective concentration: > 10000 nM
Compound 4 was reported as a limit (the forecaster's own chance of this, stated with the estimate: 70%); the middle value sits exactly at the limit.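

The steps from compound 1, compound 2 and compound 3 to compound 4 cannot be read in this assay, due to a shared limit: the limit of > 10000 nM in this assay, at which 4 of the 4 values shown sit.

The compounds shown leave open whether any substituent on this aromatic carbon of the shared core gives a readable number in this assay.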